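Halogen Swaps on the Carbonyl Aryl Ring: Estimating Compound 3

The source may report more compounds than this note shows. Statements on the series, on what has been measured and on what is new or still open speak of the compounds shown alone.

Compound 1 `COc1cc(-c2cc(/C=C/C(=O)c3ccc(N)cc3)[nH]n2)cc(OC)c1OC`: -89% in a functional assay on BT-549 cells (Homo sapiens) for cytotoxicity, read by sulforhodamine B assay, with a stated time of 48 h, tested at 10 uM; on this read-out lower numbers stand for a stronger effect and higher numbers for a weaker effect at the one concentration tested
Compound 2 `COc1cc(-c2cc(/C=C/C(=O)c3ccc(Cl)c(Cl)c3)[nH]n2)cc(OC)c1OC`: 47%

Of the two measured compounds, compound 1 stands lowest in this assay; its nearest neighbour is compound 2, a number 136 percentage points higher from compound 1 to compound 2 (beyond the scatter). Compound 3 `COc1cc(-c2cc(/C=C/C(=O)c3ccc(F)c(F)c3)[nH]n2)cc(OC)c1OC` differs from compound 1 as follows: 3,4-difluorophenyl in place of 4-aminophenyl on a carbonyl carbon. Within the data shown here, the only measured step bearing on this is the one from compound 1 to compound 2, 3,4-dichlorophenyl in place of 4-aminophenyl on a carbonyl carbon, which was large and upward. A large upward step is therefore expected here as well, a number 129 percentage points higher from compound 1 to compound 3 (beyond the scatter). Compound 3 is estimated at 40%, within a range from 5% to 75%.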

Compound 3, a percentage reported as activity, at one concentration (the size of the read-out at that concentration, not a potency): 23%
For compound 3 the middle estimate is 17 percentage points above the measured one; low and high end bracket the measured number.
By their numbers in this assay, from the lowest: compound 1; then compound 3; then compound 2.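

In this assay the second dihalogen swap reads a number 112 percentage points higher from compound 1 to compound 3 (beyond the scatter) and so shows that the large loss of effect on leaving 4-aminophenyl is not confined to 3,4-dichlorophenyl. The identity of the halogen also matters on this carbonyl carbon, as the change between the two halogenated rings gives a number 24 percentage points lower from compound 2 to compound 3 (beyond the scatter) and leaves the difluoro compound with the stronger effect of that pair. No evidence is available here to explain either step.

On these data alone, it remains open whether a phenyl ring carrying a dimethylamino group on this carbonyl carbon would stay close to compound 1. A ring with a single fluorine is equally unresolved.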